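The compounds below may be only part of what the source reports. "The series", "measured", "known", "first", "only" and "open" are said of these compounds alone.

Of the compounds shown here, two have been measured in a functional assay on MCF7 cells (Homo sapiens) for inhibition, read by MTT assay, with a stated time of 72 h; on this read-out higher numbers stand for weaker inhibition and lower numbers for stronger inhibition. Compound 1 `COc1cc2c(Oc3ccc(NC(=O)c4nn(-c5ccccc5C)cc(C)c4=O)cc3)ccnc2cc1OCCCCCC(=O)NO` gives 1830 nM in this assay. Compound 2 `COc1cc2c(Oc3ccc(NC(=O)c4nn(-c5ccccc5F)cc(C)c4=O)cc3F)ccnc2cc1OCCCCCC(=O)NO` gives 2320 nM in this assay. Compound 1 has the lower of these two numbers, but the gap to compound 2 lies within the usual scatter of repeated measurements, so the two cannot be told apart on this evidence.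

Compound 3 `COc1cc2c(Oc3ccc(NC(=O)c4nn(-c5ccccc5C)ccc4=O)cc3)ccnc2cc1OCCCCCC(=O)NO` has not yet been measured. It differs from compound 1 in one place: hydrogen in place of methyl on an aromatic carbon. Among the compounds with values here, no pair of measured compounds differs at this site, so the data give no step size for this kind of change. On this basis the step from compound 1 to compound 3 is expected to be small, a 1.2-fold higher number from compound 1 to compound 3 (0.08 log units; within the scatter), in either direction or none beyond the scatter. The value of compound 3 in this assay is therefore estimated at 2200 nM, with a range from 900 nM to 5500 nM.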

Compound 3, half-maximal inhibitory concentration: 4360 nM
Compound 3: middle estimate off by 2.0-fold (0.30 log units), on the low side, within the range that was stated.
By their numbers in this assay, from the lowest: compounds 1, 2 and 3 (each within the scatter of the next, the first and the last beyond it).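

Replacing methyl with hydrogen on this aromatic carbon gives a 2.4-fold higher number from compound 1 to compound 3 (0.38 log units; beyond the scatter) in this assay, so inhibition becomes modestly weaker. Within the data shown here, this is the first measured step at this position, and it shows that the methyl cannot be removed without a change larger than the usual scatter, at least in compound 1. Nothing measured here explains the step.

On these data alone, with only methyl and hydrogen compared at this carbon, it remains open whether an ethyl group, a methoxy group, a chlorine atom or an amine would restore, strengthen or further weaken inhibition. This single pair also leaves open whether removing the methyl would have a similar effect in compound 2, which differs from compound 1 elsewhere in its structure.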